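Lengthening the Hydroxamate Linker by One Carbon

The compounds below may be only part of what the source reports. "The series", "measured", "known", "first", "only" and "open" are said of these compounds alone.

Compound 2 `C#CCN(C)Cc1cccc(NC(=O)CCCC(=O)NO)c1` was tested in a functional assay on DU-145 cells (Homo sapiens) for inhibition, read by MTT assay, with a stated time of 48 h; on this read-out higher numbers stand for weaker inhibition of growth and lower numbers for stronger inhibition of growth. In this assay compound 2 gives only a limit of the assay, > 10000 nM, and not a number. Compound 1 `C#CCN(C)Cc1cccc(NC(=O)CCC(=O)NO)c1` likewise gives only a limit in this assay, > 10000 nM. Among the measured compounds shown here, the one measured step, a step that the two limits leave unreadable from compound 1 to compound 2, therefore cannot be read in size or direction, since (the limit of > 10000 nM in this assay, at which 2 of the 2 values shown sit). Compound 3 `C#CCN(C)Cc1cccc(NC(=O)CCCCC(=O)NO)c1` carries the change ((hydroxycarbamoyl)methyl in place of hydroxycarbamoyl on a saturated chain carbon, three bonds along the chain from a carbonyl carbon). For the measured compounds named here, no measured step speaks to this change beyond what the two limits show, so neither a direction nor a size can be drawn from the numbers so far. Compound 3 is expected to fall near 8000 nM, within 2000 nM to 30000 nM. That estimate means an expected step of an at least 1.2-fold lower number from compound 2 to compound 3 (0.09 log units; that floor lies within the scatter), and a further limit rather than a number remains the likelier outcome for compound 3.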

Compound 3, concentration for 50% growth inhibition: 9750 nM
Compound 3: middle estimate off by 1.2-fold (0.09 log units), on the low side; the range from low to high includes it.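

Among the compounds shown here, compound 3 is the first of these chains to give a number rather than a limit in this assay, so the chain length can now be tied to a measured value on one side. Swapping hydroxycarbamoyl for (hydroxycarbamoyl)methyl at this position gives an at least 1.0-fold lower number from compound 2 to compound 3 (0.01 log units; that floor lies within the scatter), and the 2-(hydroxycarbamoyl)ethyl change gives an at least 1.0-fold lower number from compound 1 to compound 3 (0.01 log units; that floor lies within the scatter). Neither floor establishes a real drop, because the two shorter chains are known only as limits: the limit of > 10000 nM in this assay, at which 2 of the 3 values shown sit.

The compounds shown leave open whether a longer chain than that of compound 3 would bring the number clearly down. They also do not show what a carboxylic acid in place of the hydroxycarbamoyl group would do on this chain.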